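The source may hold more compounds than are shown below. What is called first, only, known or untested is meant among the compounds shown, and "the series" means these compounds.

Compound 1, `CC(C)COc1cc(C(F)(F)F)ccc1CNC(=O)C(C)c1ccc(NS(C)(=O)=O)c(F)c1`, gives 0.8 nM in an assay on CHO cells for antagonist activity at transient receptor potential cation channel subfamily V member 1 (Homo sapiens), read by FLIPR; a higher number here means a weaker inhibitor, a lower number a stronger inhibitor. Compound 2, `CCCCCCSc1cc(C(F)(F)F)ccc1CNC(=O)C(C)c1ccc(NS(C)(=O)=O)c(F)c1`, gives 1.8 nM in this assay. Compound 3, `CC(C(=O)NCc1ccc(C(F)(F)F)cc1Cl)c1ccc(NS(C)(=O)=O)c(F)c1`, gives 4 nM in this assay.

Compound 3 thus carries the highest of the three numbers, with a 5.0-fold higher number from compound 1 to compound 3 (0.70 log units; beyond the scatter) and a 2.2-fold higher number from compound 2 to compound 3 (0.35 log units; beyond the scatter). Compound 4 is `CC(C(=O)NCc1ccc(C(F)(F)F)cc1-c1ccc(C(C)(C)C)cc1)c1ccc(NS(C)(=O)=O)c(F)c1`; the change is 4-(tert-butyl)phenyl in place of chloro on an aromatic carbon. The measured steps that bear on it are those in which a group on an aromatic carbon is exchanged: a 5.0-fold higher number from compound 1 to compound 3 (0.70 log units; beyond the scatter) and a 2.2-fold higher number from compound 2 to compound 3 (0.35 log units; beyond the scatter), both modest, both with the larger group giving the lower number. A modest step to a lower number in this assay is therefore expected, a 2.0-fold lower number from compound 3 to compound 4 (0.30 log units; within the scatter). Compound 4 is estimated at 2 nM, in the range 0.5 nM to 8 nM.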

Compound 4, inhibition constant: 1.1 nM
Compound 4: middle estimate off by 1.8-fold (0.26 log units), on the high side; low and high end bracket the measured number.
By their numbers in this assay, from the lowest: compounds 1, 4 and 2 (each within the scatter of the next, the first and the last beyond it); then compound 3.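

Among the compounds shown here, at this position an aromatic ring appears for the first time, and 4-(tert-butyl)phenyl in place of chloro gives a 3.6-fold lower number from compound 3 to compound 4 (0.56 log units; beyond the scatter) in this assay. Measured against the two non-ring groups, it gives a 1.6-fold lower number from compound 2 to compound 4 (0.21 log units; within the scatter) and a 1.4-fold higher number from compound 1 to compound 4 (0.14 log units; within the scatter), so a group of this size and shape cannot be set apart from hexylsulfanyl or isobutoxy here. Nothing available accounts for these numbers.

The compounds shown leave open how an unsubstituted phenyl or a pyridine would read at this position in this assay. They also leave open what an amine or a carboxylic acid on the entering ring would do.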